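The source may report more compounds than this note shows. Statements on the series, on what has been measured and on what is new or still open speak of the compounds shown alone.

In a functional assay on HL-60 cells (Homo sapiens) for inhibition (on this read-out lower numbers stand for stronger inhibition and higher numbers for weaker inhibition), three compounds that share one core have been measured, and they differ only in the group on an aromatic nitrogen. Compound 1 `CCn1nc(-c2ccc(OC)cc2)c(-c2ccc(OC)cc2)cc1=O`, which carries ethyl there, gives 610 nM. Compound 3 `COc1ccc(-c2cc(=O)n(C(C)C)nc2-c2ccc(OC)cc2)cc1`, which carries isopropyl, gives 1320 nM, the higher of the two actual numbers in this small set. Compound 2 `COc1ccc(-c2cc(=O)n(CC(C)C)nc2-c2ccc(OC)cc2)cc1`, which carries isobutyl, gives > 100000 nM, and this is a limit of the assay, not a number.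

Compound 4 `COc1ccc(-c2cc(=O)n(C3CC3)nc2-c2ccc(OC)cc2)cc1` has not yet been measured. It has cyclopropyl in place of isopropyl on an aromatic nitrogen, which brings in a three-membered non-aromatic ring of carbon only.

Among the compounds with values here, three measured steps bear on this change, all at the same place on the core. Going from ethyl to isopropyl was a modest step, a 2.2-fold higher number from compound 1 to compound 3 (0.34 log units; beyond the scatter). Going to isobutyl was far larger, an at least 160-fold higher number from compound 1 to compound 2 (2.21 log units; beyond the scatter), and the step back to isopropyl was also large, an at least 75-fold lower number from compound 2 to compound 3 (1.87 log units; beyond the scatter). Cyclopropyl resembles isopropyl more than isobutyl, so the modest step of a 2.2-fold higher number from compound 1 to compound 3 (0.34 log units; beyond the scatter) is the better guide, and no shift beyond the scatter is expected in this assay. The expected step is a 1.1-fold lower number from compound 3 to compound 4 (0.04 log units; within the scatter). For compound 4 the estimated value is 1200 nM, with an expected range of 350 nM to 5000 nM.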

Compound 4, half-maximal inhibitory concentration: 7980 nM
Compound 4: middle estimate off by 6.7-fold (0.82 log units), on the low side, and the stated range ends below it.
By their numbers in this assay, from the lowest: compound 1; then compound 3; then compound 4. At a limit, above all of these: compound 2.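

In this assay, isopropyl and cyclopropyl are not interchangeable on this aromatic nitrogen, even though both have 3 heavy atoms, all carbon: the change to the three-membered ring gives a 6.0-fold higher number from compound 3 to compound 4 (0.78 log units; beyond the scatter). Within the data shown here, measured against ethyl, the change is larger still, at a 13-fold higher number from compound 1 to compound 4 (1.12 log units; beyond the scatter), so isobutyl is no longer the only group here that moves the number well away from that of ethyl. Cyclopropyl still reads far better than isobutyl, with an at least 12-fold lower number from compound 2 to compound 4 (1.09 log units; beyond the scatter), but this step starts from a limit and not from a number, so its true size stays unknown: the limit of > 100000 nM in this assay, at which 1 of the 4 values shown sits.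

Still open, from the compounds shown here alone, is how a cyclobutyl group or a plain methyl on this nitrogen would read, which would help show whether the ring itself or the overall shape of the group tracks with the loss of inhibition. All of this rests on this assay alone, and the compounds shown do not explain why the groups fall in this order.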